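A Tetrazole in Place of a Sulfonamide: One Step

The source may hold more compounds than are shown below. What is called first, only, known or untested is meant among the compounds shown, and "the series" means these compounds.

Three compounds have been measured in a functional assay for antagonist activity at transient receptor potential cation channel subfamily V member 1 (Rattus norvegicus); on this read-out higher numbers stand for weaker inhibition and lower numbers for stronger inhibition:
compound 1, `C[C@@H]1CN(c2ncccc2C(F)(F)F)CCN1C(=O)Nc1ccc(C(F)(F)F)cc1`, gives 11 nM
compound 2, `Cc1cccnc1-c1ccc(C(=O)Nc2ccc(Cl)cc2)cc1`, gives 2020 nM
compound 3, `CC(C)(C)c1ccc(NC(=O)c2ccc(-c3ncccc3NS(C)(=O)=O)cc2)cc1`, gives 35 nM

Among these, compound 3 holds the second highest number of the three: its value lies above that of compound 1 by a margin beyond the usual scatter, and far below that of compound 2. Compound 4, `CC(C)(C)c1ccc(NC(=O)c2ccc(-c3ncccc3-c3nn[nH]n3)cc2)cc1`, has not yet been measured. It differs from compound 3 in one place: 2H-tetrazol-5-yl in place of methanesulfonamido on an aromatic carbon. Both the leaving and the entering group carry 1 hydrogen-bond donor, but the entering group brings one five-membered aromatic ring with 4 hetero atoms where the leaving group had no ring. For the measured compounds named here, no pair of measured compounds shows this change, so there is no measured precedent to lean on. A modest weakening of inhibition in this assay is expected, a 2.6-fold higher number from compound 3 to compound 4 (0.41 log units; beyond the scatter), somewhat beyond the scatter. Compound 4 is estimated at 90 nM, within a range from 20 nM to 400 nM.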

Compound 4, half-maximal inhibitory concentration: > 4000 nM
Compound 4: no number, only a limit; the forecaster's own chance of this, stated with the estimate: 5%; middle value at least 44-fold (1.64 log units) from the limit.
By their numbers in this assay, from the lowest: compound 1; then compound 3; then compound 2. At a limit, above all of these: compound 4.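

In this assay compound 4 gives > 4000 nM, which is a limit of the assay and not a number. Replacing methanesulfonamido with 2H-tetrazol-5-yl at this position brings a large loss of inhibition, an at least 110-fold higher number from compound 3 to compound 4 (2.05 log units; beyond the scatter), so sharing 5 heavy atoms and 1 hydrogen-bond donor is not enough to keep it. The full size of this step cannot be read past that limit: the limit of > 4000 nM in this assay, at which 1 of the 4 values shown sits.

Still open, on these data alone, is whether the loss is specific to 2H-tetrazol-5-yl. A carboxylic acid or an amine on the same carbon would help to show how narrowly this position is defined.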